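The compounds below may be only part of what the source reports. "The series", "measured", "known", "first", "only" and "open" are said of these compounds alone.

Of the compounds shown here, three sharing one core have been measured in a functional assay on KB cells (Homo sapiens) for antiproliferative activity, read by sulforhodamine B assay, with a stated time of 3 days; on this read-out lower numbers stand for an effect already at smaller amounts and higher numbers for an effect only at larger amounts of compound. Compound 1 `CCC1=C(O)c2c(oc(-c3ccc(OC)cc3)cc2=O)C(CC)(CC)C1=O` gives 17.7 uM. Compound 2 `CCC1=C(O)c2c(oc(-c3ccc(OC)c(OC)c3)cc2=O)C(CC)(CC)C1=O` gives 14.7 uM in this assay, and compound 3 `CCC1=C(O)c2c(oc(-c3cc(C)c(OC)cc3C)cc2=O)C(CC)(CC)C1=O` gives 36.6 uM. Among these three numbers compound 1 stands second highest; compound 2 lies nearest to it, whereas compound 3 lies furthest, and the gap from compound 1 to compound 3 is beyond the scatter. Among the measured compounds shown here, the only single-place step recorded is a 1.2-fold lower number from compound 1 to compound 2 (0.08 log units; within the scatter), which is within the scatter. Compound 4 `CCC1=C(O)c2c(oc(-c3ccc(O)c(O)c3)cc2=O)C(CC)(CC)C1=O` is not yet measured; compared with compound 1 it carries 3,4-dihydroxyphenyl in place of 4-methoxyphenyl on an aromatic carbon. For the measured compounds named here, the step from compound 1 to compound 2, which also changes the substitution of that aromatic ring, is the one that bears on this change, and it was small; no step in which a methoxy gives way to a hydroxy is available. The account therefore expects no movement in this assay beyond the scatter, that is an estimated 1.1-fold lower number from compound 1 to compound 4 (0.04 log units; within the scatter). Compound 4 is estimated at 16 uM, with a range from 6 uM to 45 uM.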

Compound 4, concentration for half-maximal effect: 10 uM
For compound 4 the middle estimate is 1.6-fold (0.20 log units) above the measured one; measured number inside the range.
By their numbers in this assay, from the lowest: compounds 4, 2 and 1 (each within the scatter of the next); then compound 3.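

The exchange of 4-methoxyphenyl for 3,4-dihydroxyphenyl on this aromatic carbon next to the ring oxygen gives in this assay a 1.8-fold lower number from compound 1 to compound 4 (0.25 log units; within the scatter) and so stays within the scatter. The earlier compounds shown here carried only methoxy and methyl groups on this ring, whereas the entering group here brings hydrogen-bond donors and the leaving group has none, and this exchange alone does not move the number beyond the scatter. No measurement available here explains this outcome.

As far as these compounds go, it remains open whether a single hydroxy group, an amine or a carboxylic acid on this ring would also stay within the scatter of compound 1. From the compounds shown here alone, it also remains open whether the ethyl groups on the shared core could give way to longer chains without a larger step.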